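A few compounds are considered here, and "the series" means these few. Any claim that something is new, unique, unknown or untested is made for them only; others in the source may bear on it.

Measured in a functional assay on HCT-116 cells (Homo sapiens) for inhibition, read by colorimetric assay, with a stated time of 3 days; on this read-out higher numbers stand for weaker inhibition and lower numbers for stronger inhibition:
compound 1, `O=C(CCCCCCNC(=O)C(O)(O)C(F)(F)F)Nc1cccc(Br)c1`: 3060 nM
compound 2, `COc1ccccc1NC(=O)CCCCCCNC(=O)C(O)(O)C(F)(F)F`: 10100 nM
compound 3, `O=C(CCCCCCNC(=O)C(O)(O)C(F)(F)F)Nc1ccc(Cl)cc1`: 4230 nM

Compound 3 gives the second highest of the three numbers. Its nearest neighbour is compound 1, a 1.4-fold higher number from compound 1 to compound 3 (0.14 log units; within the scatter), a gap within the scatter; its furthest is compound 2, a 2.4-fold lower number from compound 2 to compound 3 (0.38 log units; beyond the scatter), beyond the scatter.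

Among the measured compounds shown here, compound 4, `COc1ccc(NC(=O)CCCCCCNC(=O)C(O)(O)C(F)(F)F)cc1`, is the next compound to be run. methoxy in place of chloro on an aromatic carbon The entering methoxy sits para to a large group, whereas the only measured methoxy compound, compound 2, carries it as 2-methoxyphenyl, so no measured pair shows exactly this change. The two steps that touch a methoxy are a 3.3-fold higher number from compound 1 to compound 2 (0.52 log units; beyond the scatter) and a 2.4-fold lower number from compound 2 to compound 3 (0.38 log units; beyond the scatter); in both, the compound bearing the methoxy gives the higher number by a modest margin, and compound 2 carries the highest number of the three. On that basis a modest rise in this assay is expected, a 1.5-fold higher number from compound 3 to compound 4 (0.19 log units; within the scatter), with the change of position leaving the size uncertain. Compound 4 is estimated at 6500 nM, with a range from 3000 nM to 14000 nM.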

Compound 4, half-maximal inhibitory concentration: 4520 nM
For compound 4 the middle estimate is 1.4-fold (0.16 log units) above the measured one; measured number inside the range.
By their numbers in this assay, from the lowest: compounds 1, 3 and 4 (each within the scatter of the next); then compound 2.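

In this assay, methoxy in place of chloro on an aromatic carbon, para to a large group, leaves the two compounds indistinguishable: a 1.1-fold higher number from compound 3 to compound 4 (0.03 log units; within the scatter). Methoxy alone therefore does not go with the higher number of compound 2, since the 4-methoxyphenyl and 2-methoxyphenyl compounds stand apart, with a 2.2-fold lower number from compound 2 to compound 4 (0.35 log units; beyond the scatter). The comparison with the 3-bromophenyl compound also stays inside the scatter, with a 1.5-fold higher number from compound 1 to compound 4 (0.17 log units; within the scatter), so compound 1, compound 3 and compound 4 cannot be ordered here, and only compound 2 stands off from all three. Nothing on hand explains these numbers.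

Going by these compounds, whether the gap belongs to the 2-methoxyphenyl group alone or would recur with 2-chlorophenyl remains open. So does the effect of an amine or a carboxylic acid on the ring, or of a longer chain.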